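This account rests on a few compounds, and the source may have more. Where it says the series, first, only, none or still open, it means among the compounds named here.

Measured so far:
Compound 1, `CC1=NN(c2ccc(C)cc2)C(=O)C12C=CC(=O)C=C2c1ccc(C)cc1`: in a functional assay on A549 cells (Homo sapiens) for antiproliferative activity, read by CCK-8 assay, with a stated time of 72 h (a higher number here means a weaker inhibitor, a lower number a stronger inhibitor), compound 1 gives 37000 nM.
Compound 2, `CC1=NN(c2ccccc2)C(=O)C12C=CC(=O)C=C2c1cccc(C)c1`: in this assay compound 2 gives 16500 nM.

Compound 2 holds the lower of the two numbers; the gap up to compound 1 lies beyond the usual scatter.

Compound 3, `CC1=NN(c2ccccc2)C(=O)C12C=CC(=O)C=C2c1ccc(C)cc1`, differs from compound 2 by one change: 4-methylphenyl in place of 3-methylphenyl on a double-bonded ring carbon. Within the data shown here, no measured pair shows this change alone, so the direction is open; a small rise in this assay, not clearly beyond the scatter, is expected.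

For compound 3 the estimate in this assay is 22000 nM, within 8000 nM to 60000 nM. The expected step is a 1.3-fold higher number from compound 2 to compound 3 (0.12 log units; within the scatter).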

Compound 3, half-maximal inhibitory concentration: 19300 nM
Beside the measured number, compound 3's estimate is 1.1-fold (0.06 log units) above it, within the range that was stated.
By their numbers in this assay, from the lowest: compounds 2, 3 and 1 (each within the scatter of the next, the first and the last beyond it).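

In this assay, 4-methylphenyl in place of 3-methylphenyl on the double-bonded ring carbon gives a 1.2-fold higher number from compound 2 to compound 3 (0.07 log units; within the scatter), so at this position the two methylphenyl groups are not told apart. Hydrogen in place of methyl on an aromatic carbon gives a 1.9-fold lower number from compound 1 to compound 3 (0.28 log units; within the scatter), so this change is not told apart from the scatter either. Nothing measured offers an explanation for either step.

Still open, as far as these compounds go, is whether a group other than methyl on these aromatic rings, such as an amine, a methoxy group or a carboxylic acid, shifts the number beyond the scatter. Replacing the methylphenyl group on the double-bonded ring carbon with a longer chain also remains untested in the compounds shown.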